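A few compounds are considered here, and "the series" means these few. Any claim that something is new, unique, unknown or untested is made for them only; others in the source may bear on it.

Measured compounds in an assay on isolated protein for inhibition of DNA topoisomerase 1 (Homo sapiens), with a stated time of 15 min; a higher number here means a weaker inhibitor, a lower number a stronger inhibitor:
- compound 1, `CNC[C@@H]1CCN(c2cc3c(cc2F)c(=O)c(C(=O)O)cn3Cc2ccc(-n3cccn3)cc2)C1`: > 200000 nM (a limit of the assay, not a number)
- compound 2, `O=C(O)c1cn(Cc2ccc(-n3cccn3)cc2)c2cc(NC[C@H]3CCNC3)c(F)cc2c1=O`: 187000 nM
- compound 3, `O=C(O)c1cn(Cc2ccc(-n3cccn3)cc2)c2cc(NC[C@@H]3CCNC3)c(F)cc2c1=O`: 200000 nM

Compound 1 stands only at a limit in this assay; its reading is > 200000 nM and no number is attached to it. The step of an at least 1.0-fold lower number from compound 1 to compound 2 (0.02 log units; that floor lies within the scatter) sits at a floor within the scatter, and the step of a number no higher from compound 1 to compound 3 (the limit leaves the size open) leaves its size open. Between compound 2 and compound 3, which differ only in the configuration drawn at one saturated ring carbon, the step of a 1.1-fold higher number from compound 2 to compound 3 (0.03 log units; within the scatter) is within the scatter; this rests on the fact that compounds 2 and 3 differ only in the configuration as drawn and on (the limit of > 200000 nM in this assay, at which 1 of the 3 values shown sits).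

Compound 4, `CNC[C@@H]1CCN(c2cc3c(cc2F)c(=O)c(C(=O)O)cn3Cc2ccc(-c3ccccc3)cc2)C1`, carries the change (phenyl in place of 1H-pyrazol-1-yl on an aromatic carbon). For the measured compounds named here, none of the measured steps touches this position: all three change the amine side of the shared core, and all three values sit at or close to the limit. There is therefore no basis for expecting a step beyond the scatter, and the number for compound 4 is expected to stay near the limit, with the estimated step of a number no higher from compound 1 to compound 4 (the limit leaves the size open). The estimate for compound 4 in this assay is 200000 nM, between 100000 nM and 400000 nM.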

Compound 4, half-maximal inhibitory concentration: 168000 nM
Compound 4: the middle estimate sits 1.2-fold (0.08 log units) above what was measured, within the range that was stated.
By their numbers in this assay, from the lowest: compounds 4, 2 and 3 (each within the scatter of the next).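

For the compounds shown here, this is the first reading at the position held by the 1H-pyrazol-1-yl group, on an aromatic carbon para to a large group, and in this assay phenyl in its place gives an at least 1.1-fold lower number from compound 1 to compound 4 (0.07 log units; that floor lies within the scatter). Compound 4 gives 168000 nM, so with this amine on the shared core and phenyl at this position the read-out is a number and not a limit, even though the five-membered aromatic ring with 2 hetero atoms and 2 hydrogen-bond acceptors has given way to a six-membered aromatic ring of carbon only. Compound 1 stands at a limit and not at a number, so the step is only a floor and its true size stays unread because of where that compound sits: the limit of > 200000 nM in this assay, at which 1 of the 4 values shown sits.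

Still open, going by these compounds, is whether any group at this position gives a step clearly beyond the scatter in this assay, for instance a morpholin-4-yl ring, a primary amide or a small methyl group in place of the phenyl. Also open, on these data alone, is whether a substituent on the phenyl ring itself, such as an amine or a carboxylic acid, moves the number away from this high range.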